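This account rests on a few compounds, and the source may have more. Where it says the series, first, only, none or still open, it means among the compounds named here.

In a functional assay on the whole organism for inhibition, with Rattus norvegicus as the target, read by paw edema, with stated times of 30 min and 2 h, at a dose of 0.28 mmol/kg by the oral route (on this read-out higher numbers stand for more inhibition at the one dose given (going by the name of the read-out) and lower numbers for less inhibition), compound 1 `CNC(=O)c1nc(-c2cc(OC)c(OC)c(OC)c2)n(-c2ccc(OC)cc2)n1` gives 74%, compound 2 `COc1ccc(-n2nc(C(=O)Nc3ccc(C)cc3)nc2-c2cc(OC)c(OC)c(OC)c2)cc1` gives 60% and compound 3 `COc1ccc(-n2nc(C(=O)Nc3ccccc3C)nc2-c2cc(OC)c(OC)c(OC)c2)cc1` gives 30%. Compound 2 therefore stands second of the three, lying a number 14 percentage points lower from compound 1 to compound 2 (beyond the scatter) and a number 30 percentage points lower from compound 2 to compound 3 (beyond the scatter). Compound 4 `COc1ccc(-n2nc(C(=O)Nc3ccccc3)nc2-c2cc(OC)c(OC)c(OC)c2)cc1` differs from compound 2 by hydrogen in place of methyl on an aromatic carbon. Within the data shown here, no measured step removes this methyl outright; the steps touching the same amide-type nitrogen were a number 44 percentage points lower from compound 1 to compound 3 (beyond the scatter), the large one, and the two modest ones already named, which concern a different change than the one at hand. The step for compound 4 is thus expected to be small, a number 2 percentage points lower from compound 2 to compound 4 (within the scatter). Compound 4 is estimated to give 58% in this assay, within a range of 40% to 75%.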

Compound 4, a percentage reported as inhibition, in the whole organism at one dose (the size of the read-out at that dose, not a potency): 51%
Estimate against measurement, compound 4: 7 percentage points above; the measured number falls inside the stated range.
By their numbers in this assay, from the lowest: compound 3; then compounds 4 and 2 (each within the scatter of the next); then compound 1.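

In this assay, the change from 4-methylphenyl to phenyl on the amide-type nitrogen leaves the reading within the scatter (a number 9 percentage points lower from compound 2 to compound 4 (within the scatter)). The same replacement of methyl by hydrogen starting from compound 3 does register (a number 21 percentage points higher from compound 3 to compound 4 (beyond the scatter)), so among these compounds its effect depends on where the methyl stands, and the phenyl amide still trails the methyl amide (a number 23 percentage points lower from compound 1 to compound 4 (beyond the scatter)). Nothing available accounts for these differences. From the compounds shown here alone, what an amine or a carboxylic acid in place of this methyl would give stays open, as does a longer chain than methyl on the amide-type nitrogen.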